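Purine series, cytotoxicity on renal carcinoma cells: amino step

The compounds below may be only part of what the source reports. "The series", "measured", "known", "first", "only" and "open" are said of these compounds alone.

Measured compounds:
compound 1 `ClCc1ccccc1Cn1cnc2c(Cl)nc(Cl)nc21`, 4160 nM
compound 2 `ClCc1ccccc1Cn1cnc2c(Cl)ncnc21`, 26900 nM
compound 3 `ClCc1ccc(Cn2cnc3nc(Cl)nc(Cl)c32)cc1`, 5750 nM

The read-out throughout is a functional assay on ACHN cells (Homo sapiens) for cytotoxicity, read by sulforhodamine B assay, with a stated time of 48 h; on this read-out higher numbers stand for lower toxicity in this test and lower numbers for higher toxicity in this test. Compound 2 stands at the highest of the three numbers, which here means the least toxic of the set. Its nearest neighbour is compound 3, and the gap to compound 1 is the largest. Among the measured compounds shown here, the one single-point step among the measured compounds is a 6.5-fold higher number from compound 1 to compound 2 (0.81 log units; beyond the scatter); it shows that removing a chloro group at this place of the shared core lifts the number clearly beyond the scatter.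

Compound 4 `Nc1nc(Cl)c2ncn(Cc3ccccc3CCl)c2n1` differs from compound 2 by amino in place of hydrogen on an aromatic carbon. This is the same carbon at which compound 1 carries a chloro group. For the measured compounds named here, no measured pair covers an amino group at this place, so the step from compound 1 to compound 2 is the only guide. That step shows the carbon is sensitive to substitution; an amino group is a different substituent from chloro, so the direction cannot be read off directly, and an expectation of a modest move back toward lower numbers, with wide uncertainty, seems prudent. Compound 4 is therefore expected at 12000 nM, within 3500 nM to 40000 nM, corresponding to an estimated step of a 2.2-fold lower number from compound 2 to compound 4 (0.35 log units; beyond the scatter).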

Compound 4, concentration lethal to 50% of the cells: 75900 nM
The estimate for compound 4 lay 6.3-fold (0.80 log units) below the measured number; measured number above the stated range.
By their numbers in this assay, from the lowest: compounds 1 and 3 (each within the scatter of the next); then compound 2; then compound 4.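

In this assay, the aromatic carbon between two ring nitrogen atoms now responds in both directions: chloro there goes with a lower number than hydrogen, as a 6.5-fold higher number from compound 1 to compound 2 (0.81 log units; beyond the scatter) shows, whereas amino in place of hydrogen gives a 2.8-fold higher number from compound 2 to compound 4 (0.45 log units; beyond the scatter). The direction at this carbon therefore depends on the group that enters, not merely on hydrogen being replaced, and the exchange of chloro for amino gives an 18-fold higher number from compound 1 to compound 4 (1.26 log units; beyond the scatter), a wider span than either step from hydrogen. Nothing available bears on what lies behind this difference between chloro and amino.

On these data alone, with only hydrogen, chloro and amino compared at this carbon, it remains open whether a methylamino, dimethylamino or hydroxyl group would follow amino or chloro, or fall between them. Also open, as far as these compounds go, is whether the amino step carries over to compound 3, where the chloromethyl group and the attachment to the shared core differ from those in compound 2.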